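This account rests on a few compounds, and the source may have more. Where it says the series, first, only, none or still open, it means among the compounds named here.

Measured compounds in an assay for binding affinity to leukotriene B4 receptor 1 (Homo sapiens); on this read-out higher numbers stand for weaker inhibition and lower numbers for stronger inhibition:

- compound 3 `COc1ccc(CCCCCCCCOc2ccc(CSc3ccccc3)nc2/C=C/C(=O)O)cc1`: 74 nM
- compound 1 `COc1ccc(CCCCCCCCOc2ccc(CSc3cccc(C(=O)O)c3)nc2/C=C/C(=O)O)cc1`: 80 nM
- compound 2 `COc1ccc(CCCCCCCCOc2ccc(C[S+]([O-])c3cccc(CS(=O)(=O)C(F)(F)F)c3)nc2/C=C/C(=O)O)cc1`: 225 nM

Compound 3 carries the lowest number of the three in this assay, though its gap to compound 1 is within the scatter; only compound 2 stands clearly apart from it, with a higher number. Within the data shown here, the single one-place step in the set, a 1.1-fold lower number from compound 1 to compound 3 (0.03 log units; within the scatter), is within the scatter and does not touch the part of the molecule changed here.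

Compound 4 `COc1ccc(CCCCCCCCOc2ccc(C[S+]([O-])c3cccc(N(C)C)c3)nc2/C=C/C(=O)O)cc1` differs from compound 3 in a group of 11 heavy atoms (8 carbon, 1 nitrogen, 1 oxygen, 1 sulfur; one six-membered aromatic ring of carbon only) in place of a group of 7 heavy atoms (6 carbon, 1 sulfur; one six-membered aromatic ring of carbon only), on a saturated chain carbon bound to an aromatic carbon. Among the measured compounds shown here, no measured step bears directly on this change. Compound 2 differs from compound 3 in more than one place, so its values show only that a broader alteration at the same saturated chain carbon went with a higher number. Taken as a loose guide, a modest rise beyond the scatter seems the more likely outcome, with wide uncertainty.

Compound 4 is expected at 150 nM, within a range of 55 nM to 420 nM. The expected step is a 2.0-fold higher number from compound 3 to compound 4 (0.31 log units; beyond the scatter).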

Compound 4, inhibition constant: 245 nM
Estimate against measurement, compound 4: 1.6-fold (0.21 log units) below; low and high end bracket the measured number.
By their numbers in this assay, from the lowest: compounds 3 and 1 (each within the scatter of the next); then compounds 2 and 4 (each within the scatter of the next).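

In this assay, the group entering at the saturated chain carbon goes with a higher number against both sulfanyl comparators: a 3.3-fold higher number from compound 3 to compound 4 (0.52 log units; beyond the scatter) and a 3.1-fold higher number from compound 1 to compound 4 (0.49 log units; beyond the scatter). At the aromatic carbon, dimethylamino in place of ((trifluoromethyl)sulfonyl)methyl gives a 1.1-fold higher number from compound 2 to compound 4 (0.04 log units; within the scatter), so this second substituent swap, like hydrogen in place of carboxy in a 1.1-fold lower number from compound 1 to compound 3 (0.03 log units; within the scatter), stays within the scatter, and the two compounds with oxygen on sulfur share the higher numbers. No measurement at hand accounts for this difference.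

Among the compounds shown, no pair differs only in the oxygen on sulfur, so its share cannot be separated from that of the ring substituent. Going by these compounds, whether an unsubstituted phenylsulfinyl group, or a carboxy group on that ring with the sulfur oxygen kept, would read like compound 4 remains open.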